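Methoxy to Fluoro on a Triazole Thioether Series

This account rests on a few compounds, and the source may have more. Where it says the series, first, only, none or still open, it means among the compounds named here.

Compound 1, `COc1ccc(C(=O)CSc2nnc(-c3cc(OC)c(OC)c(OC)c3)n2-c2ccc(OC)cc2)cc1`, in a functional assay on HCT-116 cells (Homo sapiens) for inhibition, read by MTT assay, with a stated time of 48 h (on this read-out higher numbers stand for weaker inhibition and lower numbers for stronger inhibition), reports only a limit, > 60000 nM.
Compound 2, `COc1ccc(-n2c(SCC(=O)c3ccc(F)cc3)nnc2-c2cc(OC)c(OC)c(OC)c2)cc1`, in this assay reports only a limit, > 60000 nM.
Compound 3, `COc1ccc(C(=O)CSc2nnc(-c3cc(OC)c(OC)c(OC)c3)n2-c2ccc(N(C)C)cc2)cc1`, in this assay reports only a limit, > 60000 nM.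

Within the data shown here, every measured compound in this set sits at the same ceiling of this assay, (the limit of > 60000 nM in this assay, at which 3 of the 3 values shown sit), so no step among them has a readable size. The change from compound 1 to compound 2 is fluoro in place of methoxy on an aromatic carbon; the step it made, a step that the two limits leave unreadable from compound 1 to compound 2, stays hidden behind the two limits. Compound 3 differs from compound 1 in its core by dimethylamino in place of methoxy on an aromatic carbon, and that step, a step that the two limits leave unreadable from compound 1 to compound 3, is likewise unreadable.

Compound 4, `COc1cc(-c2nnc(SCC(=O)c3ccc(F)cc3)n2-c2ccc(N(C)C)cc2)cc(OC)c1OC`, has not yet been measured. It stands to compound 3 exactly as compound 2 stands to compound 1: the change is fluoro in place of methoxy on an aromatic carbon, and the place is described in the same words, so it is the same change. The earlier instance of it could not be sized, and the compounds shown give no example of this change moving a value off the ceiling. The expectation for the step from compound 3 to compound 4 is therefore that a step that the limit leaves unreadable from compound 3 to compound 4 is small and most likely not readable at all. On that basis compound 4 is estimated at 90000 nM in this assay, with an expected range from 40000 nM to 250000 nM, and it is expected that the measurement again returns only a limit.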

Compound 4, half-maximal inhibitory concentration: 31100 nM
For compound 4 the middle estimate is 2.9-fold (0.46 log units) above the measured one, and the stated range ends above it.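

In this assay compound 4 gives 31100 nM, a measured number. Compound 1, compound 2 and compound 3 each stay at the ceiling, and each reports only a limit: the limit of > 60000 nM in this assay, at which 3 of the 4 values shown sit.

Fluoro in place of methoxy, carried onto the core of compound 3, gives an at least 1.9-fold lower number from compound 3 to compound 4 (0.28 log units; that floor lies within the scatter), and dimethylamino in place of methoxy, with the fluoro already present, gives an at least 1.9-fold lower number from compound 2 to compound 4 (0.28 log units; that floor lies within the scatter); both are floors rather than sizes, so the true steps may be larger, but neither floor by itself clears the scatter. This does not show that the change carries from one core to another, since the same change on the core of compound 1 cannot be read, and neither can any other step among the compounds at the ceiling, which leaves no two sized instances to set side by side.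

The compounds shown leave open whether the two changes act together or whether either alone would lift a compound off the ceiling. They also leave open how chloro or a carboxylic acid would read in place of the fluoro, or how a primary amine or morpholine would read in place of the dimethylamino.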